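A few compounds are considered here, and "the series" means these few. Any claim that something is new, unique, unknown or untested is made for them only; others in the source may bear on it.

Measured compounds:
- Compound 1 `O/N=C(\CCN1CCN(c2ccccn2)CC1)c1ccccc1Cl`: 24 nM
- Compound 2 `O/N=C(/CCN1CCN(c2ccccn2)CC1)c1ccccc1Cl`: 25 nM
- Compound 3 `Cc1ccccc1/C(CCN1CCN(c2ccccn2)CC1)=N\O`: 20.3 nM

The three measured compounds share one core and were tested in a functional assay on HEK293 cells with D(4) dopamine receptor (Homo sapiens) as the target, read by FLIPR; a higher number here means that more compound is needed for the effect, a lower number that less compound is needed. Compound 1 stands second highest of the three numbers, yet its nearest neighbour is compound 2 a 1.0-fold higher number from compound 1 to compound 2 (0.02 log units; within the scatter) and its furthest is compound 3, and both gaps lie within the scatter, so the three are indistinguishable. The first step rests on the fact (the fact that compounds 1 and 2 differ only in the configuration as drawn); the second, from compound 2 to compound 3, is a 1.2-fold lower number from compound 2 to compound 3 (0.09 log units; within the scatter).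

Compound 4 `O/N=C(\CCN1CCN(c2ccccn2)CC1)c1cccc(F)c1` is the unmeasured compound. It differs from compound 1 by 3-fluorophenyl in place of 2-chlorophenyl on a carbon with a double bond to nitrogen. For the measured compounds named here, of the measured steps, only the one from compound 2 to compound 3 concerns the aromatic substituent on this carbon, and it stayed within the scatter; no step moves the substituent from the 2-position to the 3-position of the phenyl, and none exchanges chloro for fluoro. The expectation for compound 4 is therefore a step of a 1.7-fold higher number from compound 1 to compound 4 (0.22 log units; within the scatter) in this assay, that is, no change beyond the scatter but with widened uncertainty. Compound 4 is estimated at 40 nM, ranging from 15 nM to 120 nM.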

Compound 4, half-maximal effective concentration: 17.1 nM
Beside the measured number, compound 4's estimate is 2.3-fold (0.37 log units) above it; the measured number falls inside the stated range.
By their numbers in this assay, from the lowest: compounds 4, 3, 1 and 2 (each within the scatter of the next).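

In this assay, putting 3-fluorophenyl in place of 2-chlorophenyl on a carbon with a double bond to nitrogen gave a 1.4-fold lower number from compound 1 to compound 4 (0.15 log units; within the scatter). The earlier compounds had shown only an exchange of methyl for chloro at this aromatic substituent, with a 1.2-fold lower number from compound 2 to compound 3 (0.09 log units; within the scatter), whereas this change replaces the 2-chlorophenyl as a whole and still stays within the scatter, so the number held across a wider change at this position than the earlier compounds had shown. Nothing measured here gives a reason for this result or separates the effect of the halogen from that of its place on the phenyl.

The compounds shown leave open what 3-chlorophenyl or 2-fluorophenyl would give on the core of compound 1, which would separate those two changes. They also leave open whether a methoxy or trifluoromethyl group on the phenyl would stay within the scatter.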